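Swapping a Dichlorophenyl for a Piperidinylmethyl on a Purine Core

The compounds below may be only part of what the source reports. "The series", "measured", "known", "first", "only" and "open" are said of these compounds alone.

The measured compounds:
- Compound 1 `C=CCn1c(=S)n(COCCO)c2nc(N)nc(O)c21`: in a functional assay on the whole organism with Mus musculus as the target (a higher number here means a larger maximal response, a lower number a smaller maximal response), compound 1 gives 7%.
- Compound 2 `Nc1nc(O)c2c(n1)n(C1OC(CO)[C@@H](O)[C@H]1O)c(=O)n2Cc1ccc(Cl)c(Cl)c1`: in this assay compound 2 gives 0%.
- Compound 3 `Cn1c(=O)n2c3c1c(=O)nc(N)n3CC1OC2[C@H](O)[C@@H]1O`: in this assay compound 3 gives 0%.

Compound 2 stands level with compound 3, the two together at the lowest of the three numbers, and compound 1 lies within the scatter of both. None of the three reaches a notable maximal response.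

Compound 4 `Nc1nc(O)c2c(n1)n(C1OC(CO)[C@@H](O)[C@H]1O)c(=O)n2CCN1CCCCC1` differs from compound 2 in one place: (piperidin-1-yl)methyl in place of 3,4-dichlorophenyl on a saturated chain carbon bound to an aromatic nitrogen. For the measured compounds named here, no step between two measured compounds speaks to this change, so the expectation rests on the flat, low set of numbers. The step from compound 2 to compound 4 is expected to be small, likely none beyond the scatter, with the estimate a number 3 percentage points higher from compound 2 to compound 4 (within the scatter). Compound 4 is therefore estimated to give 3%, within a range from 0% to 15%.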

Compound 4, largest response reached (reported as maximal response), in percent of the reference or control that the assay uses: 0%
For compound 4 the middle estimate is 3 percentage points above the measured one; the measured number falls inside the stated range.
By their numbers in this assay, from the lowest: compounds 2, 3, 4 and 1 (each within the scatter of the next).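

The step reads no change at the digits printed from compound 2 to compound 4 (within the scatter) in this assay when (piperidin-1-yl)methyl stands in place of 3,4-dichlorophenyl on a saturated chain carbon bound to an aromatic nitrogen. For the compounds shown here, this is the first single change that can be read here, and it shows that exchanging the aromatic carbon ring for a non-aromatic ring with a hetero atom leaves the maximal response unmoved. Nothing available explains this result. Going by these compounds, whether a carboxylic acid or a longer chain ending in a primary amine at this place would give a larger response remains open.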